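Methoxycarbonyl to Ethoxycarbonyl in an Antiproliferative Pair

This account rests on a few compounds, and the source may have more. Where it says the series, first, only, none or still open, it means among the compounds named here.

In a functional assay on NCI-H727 cells (Homo sapiens) for antiproliferative activity, with a stated time of 48 h (on this read-out lower numbers stand for stronger inhibition and higher numbers for weaker inhibition), compound 1 `CC(=O)c1ccc(-c2ccc(N3CCCC3)nn2)cc1` reports only a limit of > 25000 nM and no number. In this assay, within the data shown here, compound 2 `CCN(CC)c1ccc(-c2ccc(C(=O)OC)cc2)nn1` gives 90 nM as the only exact number available. Compound 3 `CCOC(=O)c1ccc(-c2ccc(N(CC)CC)nn2)cc1` differs from compound 2 at a single place, methoxycarbonyl to ethoxycarbonyl methyl in place of hydrogen on a saturated chain carbon bound to an oxygen next to a carbonyl group on the same core. Among the measured compounds shown here, no measured step in this assay gives the size of this change. A small, slightly weakening shift is expected, with the estimated 1.3-fold higher number from compound 2 to compound 3 (0.12 log units; within the scatter) staying within the usual scatter. Compound 3 is expected at 120 nM in an estimated range of 40 nM to 350 nM for this measurement.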

Compound 3, half-maximal inhibitory concentration: 1500 nM
Compound 3: middle estimate off by 13-fold (1.10 log units), on the low side, outside the stated range (above it).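

In this assay, a single methyl in place of hydrogen on a saturated chain carbon bound to an oxygen next to a carbonyl group gives a 17-fold higher number from compound 2 to compound 3 (1.22 log units; beyond the scatter). This shows that this position is not indifferent to the change from methoxycarbonyl to ethoxycarbonyl: even this small extension clearly weakens inhibition on the shared core. The compounds shown leave open whether a longer chain at this place would weaken inhibition further, and how a carboxylic acid or an amide in place of the ester would read. Nothing given here bears on the reason for this weakening.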